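A few compounds are considered here, and "the series" means these few. Any claim that something is new, unique, unknown or untested is made for them only; others in the source may bear on it.

In an assay on V79 cells for inhibition of cytochrome P450 11B2, mitochondrial (Homo sapiens), read by HTRF, with a stated time of 1 h (a higher number here means a weaker inhibitor, a lower number a stronger inhibitor), compound 2 `Cc1ccncc1-c1nc2cc(F)c(F)cc2n1C1CC1` gives 10.2 nM. Compound 3 `Cc1cncc(-c2nc3cc(F)c(F)cc3n2C2CC2)c1C` gives 0.2 nM, and the change between them, a methyl in place of hydrogen on an aromatic carbon, produced a 51-fold lower number from compound 2 to compound 3 (1.71 log units; beyond the scatter). Compound 1 `FC(F)(F)c1ccc2c(c1)nc(-c1cccnc1)n2C1CC1` sits at the limit of the assay and gives no number, > 10000 nM; its core differs from that of compound 2. Of the two numbers shown, compound 2 stands highest, with compound 3 as its only neighbour far below it.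

Compound 4 `Fc1cc2nc(-c3cccnc3)n(C3CC3)c2cc1F` differs from compound 2 in one place: hydrogen in place of methyl on an aromatic carbon. Within the data shown here, this is the change from compound 2 to compound 3 run backwards on the same core, so the one step that bears on it is large and points to a weaker inhibitor. Compound 1, which also carries pyridin-3-yl without the methyl, sits at the limit (the limit of > 10000 nM in this assay, at which 1 of the 3 values shown sits), but its different core leaves that only a loose hint. A large rise is expected: compound 4 is estimated at 400 nM, between 60 nM and 4000 nM, a step of a 39-fold higher number from compound 2 to compound 4 (1.59 log units; beyond the scatter).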

Compound 4, half-maximal inhibitory concentration: 2.1 nM
Compound 4: the middle estimate sits 190-fold (2.28 log units) above what was measured; measured number outside the range, below it.
By their numbers in this assay, from the lowest: compound 3; then compound 4; then compound 2. At a limit, above all of these: compound 1.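

Going from 4-methylpyridin-3-yl to pyridin-3-yl does not weaken the inhibitor as the earlier step suggested: a 4.9-fold lower number from compound 2 to compound 4 (0.69 log units; beyond the scatter) is a real gain, though a modest one. So the methyl at this place, opposite the ring nitrogen, is not what drives strong inhibition, whereas the further methyl carried by compound 3 goes with a 51-fold lower number from compound 2 to compound 3 (1.71 log units; beyond the scatter), and a methyl on this ring therefore does not act alike at every carbon. Compound 2 now stands higher than compound 3 and compound 4, and nothing measured here says why.

Going by these compounds, whether a larger group on this carbon, such as ethyl, methoxy or an amine, would raise the number further or lower it remains open. Also open, on these data alone, is what the further methyl of compound 3 would give on a ring without the methyl at this place.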